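Swapping Pyrimidin-2-yl for Pyrazin-2-yl in Compound 3

The compounds below may be only part of what the source reports. "The series", "measured", "known", "first", "only" and "open" are said of these compounds alone.

Compound 2 `Nc1ccccc1NC(=O)c1ccc(CSC(=S)N2CCN(c3ncccn3)CC2)cc1` stands highest of the two numbers measured in a functional assay on A-375 cells (Homo sapiens) for antiproliferative activity, read by CCK-8 assay, with a stated time of 72 h, tested at 8 uM (on this read-out higher numbers stand for a stronger effect at the one concentration tested and lower numbers for a weaker effect), where compound 2 gives 67.9%. For the measured compounds named here, compound 1 `Cc1ccc(N2CCN(C(=S)SCc3ccc(C(=O)Nc4ccccc4N)cc3)CC2)cc1` gives 26.4% in this assay, and a number 41.5 percentage points higher from compound 1 to compound 2 (beyond the scatter) is the only step known so far. Compound 3 `Nc1ccccc1NC(=O)c1ccc(CSC(=S)N2CCN(c3cnccn3)CC2)cc1` differs from compound 2 by pyrazin-2-yl in place of pyrimidin-2-yl on an amine nitrogen in a ring. Going by the values given here, no measured step bears directly on this exchange of two heteroaryl groups; the one known step concerns a different pair of groups and was large, so it gives little guidance here. Compound 3 is therefore expected to move only within the scatter, a step of a number 7.9 percentage points lower from compound 2 to compound 3 (within the scatter), with an estimated 60% in this assay, between 40% and 78%.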

Compound 3, a percentage reported as inhibition, at one concentration (the size of the read-out at that concentration, not a potency): 85.8%
Compound 3: middle estimate off by 25.8 percentage points, on the low side, and the stated range ends below it.
By their numbers in this assay, from the lowest: compound 1; then compound 2; then compound 3.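

In this assay the two heteroaryl groups are not interchangeable on this amine nitrogen in a ring: with the same atoms and the same counts of donors and acceptors, the change gives a number 17.9 percentage points higher from compound 2 to compound 3 (beyond the scatter) at this place. Measured against 4-methylphenyl, pyrazin-2-yl gives a number 59.4 percentage points higher from compound 1 to compound 3 (beyond the scatter) in the same place, so a second heteroaryl group also stands well above the methylphenyl compound. Nothing available explains the difference between the two rings.

The compounds shown leave open how a pyridin-2-yl group, with a single ring nitrogen, would compare at this place. They also leave open how an unsubstituted phenyl group would compare.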